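This account rests on a few compounds, and the source may have more. Where it says the series, first, only, none or still open, it means among the compounds named here.

Measured compounds:
- compound 1, `O=S(=O)(c1ccc(Cl)cc1)N1Cc2c[nH]nc2CC1c1cncnc1`: 67%
- compound 2, `CC[C@H]1Cc2n[nH]cc2[C@@H](c2ccc(Cl)cc2)N1S(=O)(=O)c1ccc(Cl)cc1`: 10%
- compound 3, `CC[C@H]1Cc2n[nH]cc2CN1S(=O)(=O)c1ccc(Cl)cc1`: 18%

In an ADME assay on microsomes from liver (Homo sapiens) for metabolic stability, using NADPH, with a stated time of 30 min, in the presence of a further agent that is not named here (a higher number here means that more of the compound is left, a lower number that less of the compound is left), compound 1 gives 67%, the highest of the three numbers; the nearest is compound 3 with 18%, and the furthest is compound 2 with 10%, both gaps beyond the scatter. Compound 4, `O=S(=O)(c1ccc(Cl)cc1)N1Cc2c[nH]nc2CC1c1cc(F)cc(F)c1`, has not yet been measured. It differs from compound 1 in one place: 3,5-difluorophenyl in place of pyrimidin-5-yl on a saturated ring carbon.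

Going by the values given here, only one measured step touches a group on a saturated ring carbon: a number 8 percentage points higher from compound 2 to compound 3 (within the scatter), and that step removes a 4-chlorophenyl rather than exchanging one aromatic ring for another, so it does not cover the present change directly. Among the compounds with values here, compound 2, which carries a chlorine-bearing phenyl at that carbon, shows 10% in this assay, while compound 1 with its pyrimidin-5-yl shows 67%; these two compounds differ in more than one place, so no step is drawn between them. On this thin basis a decrease beyond the scatter is expected for compound 4, a step of a number 32 percentage points lower from compound 1 to compound 4 (beyond the scatter) in this assay. Compound 4 is therefore estimated at 35%, with a range from 12% to 60%.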

Compound 4, percent of the compound remaining: 3%
Estimate against measurement, compound 4: 32 percentage points above; the measured number lies below the stated range.
By their numbers in this assay, from the lowest: compounds 4, 2 and 3 (each within the scatter of the next, the first and the last beyond it); then compound 1.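

In this assay, the step of a number 64 percentage points lower from compound 1 to compound 4 (beyond the scatter) shows that the aromatic ring on this saturated ring carbon, next to the ring nitrogen, can by itself make a large difference in how much compound is left. The earlier step, a number 8 percentage points higher from compound 2 to compound 3 (within the scatter), removed a 4-chlorophenyl rather than exchanging one ring for another, so it could not show this; here, a ring containing nitrogen gives way to a carbon-only ring bearing fluorine, with the rest of the molecule unchanged. No measurement here explains the size of this step.

Going by these compounds, since the ring nitrogens leave and the fluorines enter in the same step, the contribution of each remains open. A plain phenyl or a pyridin-3-yl on this carbon would help to separate the two.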